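A few compounds are considered here, and "the series" means these few. Any claim that something is new, unique, unknown or untested is made for them only; others in the source may bear on it.

Series notes on the methylidene lactone core with an aromatic substituent at the ring oxygen-bearing carbon. In a functional assay on BXPC-3 cells (Homo sapiens) for cytotoxicity, read by MTT assay, with a stated time of 72 h, tested at 1 uM (a higher number here means a weaker effect of the compound at the concentration tested, a lower number a stronger effect), compound 1 `C=C1C(=O)O[C@H](c2ccc3ccccc3c2)[C@H]1C` gives 104%, compound 2 `C=C1C(=O)O[C@@H](c2ccccc2)[C@H]1c1ccccc1` gives 51%, and compound 3 `C=C1C(=O)O[C@H](c2ccccc2)[C@H]1c1ccccc1` gives 86%. Compound 3 thus stands second highest of the three numbers, closer to compound 1 than to compound 2. For the measured compounds named here, the only step measured so far is a number 35 percentage points higher from compound 2 to compound 3 (beyond the scatter), a large shift that rests on the fact that compounds 2 and 3 differ only in the configuration as drawn and nothing else.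

Compound 4 `C=C1C(=O)O[C@H](c2ccc(C)cc2)[C@H]1c1ccccc1` is the next member: methyl in place of hydrogen on an aromatic carbon. Going by the values given here, no measured step involves a substituent on the aromatic ring, so the stereochemical step gives no guidance on this change, and with no comparable pair to lean on the expectation is that the step from compound 3 to compound 4 stays within the scatter, no change at the digits printed from compound 3 to compound 4 (within the scatter). For compound 4 the estimate in this assay is therefore 86%, with a range of 68% to 104%, pending the measurement.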

Compound 4, a percentage reported as activity, at one concentration (the size of the read-out at that concentration, not a potency): 67%
Beside the measured number, compound 4's estimate is 19 percentage points above it; the whole stated range lies above it.
By their numbers in this assay, from the lowest: compound 2; then compound 4; then compound 3; then compound 1.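

In this assay, methyl in place of hydrogen on an aromatic carbon, para to a large group, gives a number 19 percentage points lower from compound 3 to compound 4 (beyond the scatter). This shows that the aromatic ring is not silent to substitution at this place: a single added carbon moves the read-out toward a stronger effect, whereas the earlier step showed only a change of configuration with the atoms and bonds unchanged. Nothing at hand explains this shift, as the only available observation concerns configuration and not the methyl change.

Going by these compounds, whether methoxy, an amine or a carboxylic acid at the same place would move the read-out in the same direction remains open. Also open, on these data alone, is whether methyl has a comparable effect on the configuration drawn in compound 2.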